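The source may hold more compounds than are shown below. What is called first, only, known or untested is meant among the compounds shown, and "the series" means these compounds.

Compound 1 `Cc1ccc(C(=O)NNC(=S)Nc2csc(-c3ccccc3)c2)cc1`, compound 2 `Cc1ccc(C(=O)NNC(=S)Nc2csc(-c3ccc(C)cc3)c2)cc1` and compound 3 `COc1cc(C(=O)NNC(=S)Nc2csc(-c3ccccc3)c2)cc(OC)c1OC` share a core and were tested in a functional assay on SK-MEL-28 cells (Homo sapiens) for inhibition, read by colorimetric assay and MTT assay, with a stated time of 72 h; on this read-out lower numbers stand for stronger inhibition and higher numbers for weaker inhibition. Compound 1 gives 40000 nM, compound 2 gives 44000 nM, and compound 3 gives 55000 nM. Compound 2 differs from compound 1 by methyl in place of hydrogen on an aromatic carbon, a change that produced the step of a 1.1-fold higher number from compound 1 to compound 2 (0.04 log units; within the scatter). How the core of compound 3 differs from that of compound 1 is not broken down here. Compound 4 `COc1cc(C(=O)NNC(=S)Nc2csc(-c3ccc(C)cc3)c2)cc(OC)c1OC` has not yet been measured in this assay; it differs from compound 3 by methyl in place of hydrogen on an aromatic carbon, the same change in the same place. Compound 4 is expected to move by a 1.1-fold higher number from compound 3 to compound 4 (0.04 log units; within the scatter), because the earlier step of a 1.1-fold higher number from compound 1 to compound 2 (0.04 log units; within the scatter) stayed within the scatter. The estimate for compound 4 is 60000 nM, expected to lie between 30000 nM and 120000 nM.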

Compound 4, half-maximal inhibitory concentration: 42000 nM
The estimate for compound 4 lay 1.4-fold (0.15 log units) above the measured number; measured number inside the range.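

In this assay, the change from phenyl to 4-methylphenyl on the core of compound 3 gave a 1.3-fold lower number from compound 3 to compound 4 (0.12 log units; within the scatter). Set beside the earlier step on the core of compound 1, the new step does not differ from it: the same change on two cores in this assay, a 1.1-fold higher number (0.04 log units; within the scatter) from compound 1 to compound 2 and a 1.3-fold lower number (0.12 log units; within the scatter) from compound 3 to compound 4, 1.4-fold (0.16 log units) apart, within the scatter of two such steps. Within the data shown here, on these two cores, then, the methyl left the number within the scatter both times, but that shows only that the change stayed small on both, not that it would stay small on any other core, and with both steps this small there is no measurable effect to carry over.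

The compounds shown leave open what an amine or a carboxylic acid would do in the place of the methyl. They also leave open whether a longer chain there would give a step beyond the scatter.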